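Swapping isopropyl for acetamido: what to expect

The source may report more compounds than this note shows. Statements on the series, on what has been measured and on what is new or still open speak of the compounds shown alone.

In an ADME assay on L929 cells (Mus musculus) for cytotoxicity, read by resazurin assay, with a stated time of 96 h (a higher number here means that more compound is tolerated, a lower number that less compound is tolerated), compound 3 `CC(C)c1ccc(OC/C(=N\NC(N)=S)c2ccc(Br)cc2)cc1` gives 24600 nM. Compound 1 `Cc1ccc(/C(COc2ccc(Br)cc2)=N\NC(N)=S)cc1` gives 13200 nM, a number within the usual scatter of compound 3. Compound 2 `NC(=S)N/N=C(/COc1ccc(Br)cc1)c1cccc2ccccc12` gives 12100 nM, a lower number than compound 3 and only just beyond that scatter.

Compound 4 `CC(=O)Nc1ccc(OC/C(=N\NC(N)=S)c2ccc(Br)cc2)cc1` has not yet been measured. It carries acetamido in place of isopropyl on an aromatic carbon, para to a large group: acetamido in place of isopropyl on an aromatic carbon. Among the compounds with values here, no two measured compounds differ in only one place, so the data do not directly show what this swap does in this assay. Acetamido also appears in none of the measured compounds, which keeps the range wide. Still, the measured numbers lie close together, with compound 2 at 12100 nM and compound 3 at 24600 nM, so no step beyond the scatter is expected. The expected change is a 1.2-fold lower number from compound 3 to compound 4 (0.09 log units; within the scatter). For compound 4 the estimated value is 20000 nM, with an expected range of 8000 nM to 50000 nM.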

Compound 4, half-maximal cytotoxic concentration: 94900 nM
Beside the measured number, compound 4's estimate is 4.7-fold (0.68 log units) below it, and the stated range ends below it.
By their numbers in this assay, from the lowest: compounds 2, 1 and 3 (each within the scatter of the next, the first and the last beyond it); then compound 4.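

In this assay, the ring position para to a large group turns out not to be neutral: acetamido in place of isopropyl gives a 3.9-fold higher number from compound 3 to compound 4 (0.59 log units; beyond the scatter) and so more compound is tolerated. Within the data shown here, this is the first step here between two compounds that differ in only one place, so it is the first direct reading of what a change at this position does. Compounds 1, 2 and 3 differ in more than one place and could not show this. Nothing measured here explains why the number rises.

A single swap cannot tell whether the whole acetamido group is needed, or whether an amine or a carboxylic acid on the same aromatic carbon would move the number as far. It also leaves open whether the same swap would give a similar step on the core of compound 2.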